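The source may hold more compounds than are shown below. What is called first, only, known or untested is meant among the compounds shown, and "the series" means these compounds.

Measured compounds in this series:
compound 1 `CCCCN1CCc2nc(C#Cc3ccccc3)sc2C1` — 110 nM
compound 2 `CC(=O)N1CCc2nc(C#Cc3ccccc3)sc2C1` — > 10000 nM (a limit of the assay, not a number)
compound 3 `CC1CCC(C(=O)N2CCc3nc(C#Cc4ccccc4)sc3C2)CC1` — 190 nM

In an assay on HEK293 cells for positive allosteric modulation of metabotropic glutamate receptor 5 (Homo sapiens), read by FLIPR, with a stated time of 1 h (a higher number here means that more compound is needed for the effect, a lower number that less compound is needed), compound 1 gives 110 nM. Compound 2 reaches only the limit of this assay, > 10000 nM. Compound 3 gives 190 nM. The two steps among the measured compounds are an at least 90-fold higher number from compound 1 to compound 2 (1.95 log units; beyond the scatter) and an at least 52-fold lower number from compound 2 to compound 3 (1.72 log units; beyond the scatter). Compound 2 thus stands at the limit of > 10000 nM in this assay, at which 1 of the 3 values shown sits, so any step from it can only be read as a move away from that limit, and its size is itself only a lower bound.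

Compound 4 `O=C(C1CCOCC1)N1CCc2nc(C#Cc3ccccc3)sc2C1` is the next member to be measured. Relative to compound 2 the change is oxan-4-yl in place of methyl on a carbonyl carbon. Among the measured compounds shown here, the one measured step that bears on this is the one from compound 2 to compound 3, where a six-membered ring was likewise placed on the carbonyl carbon in place of methyl and the number fell by a large margin. The entering oxan-4-yl is of comparable size to the 4-methylcyclohexyl of compound 3, so a step of the same kind and similar size is expected, toward lower numbers: an at least 25-fold lower number from compound 2 to compound 4 (1.39 log units; beyond the scatter) is the expected step. Compound 4 is accordingly estimated at 400 nM, within a range of 100 nM to 2500 nM.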

Compound 4, half-maximal effective concentration: 290 nM
For compound 4 the middle estimate is 1.4-fold (0.14 log units) above the measured one, within the range that was stated.
By their numbers in this assay, from the lowest: compounds 1, 3 and 4 (each within the scatter of the next, the first and the last beyond it). At a limit, above all of these: compound 2.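

In this assay, a second six-membered ring on the carbonyl carbon repeats the large move away from the limit, an at least 34-fold lower number from compound 2 to compound 4 (1.53 log units; beyond the scatter), so the gain seen with 4-methylcyclohexyl is not confined to that one group. The ring oxygen of oxan-4-yl costs nothing that can be resolved against the all-carbon ring, a 1.5-fold higher number from compound 3 to compound 4 (0.18 log units; within the scatter), while the amide of compound 4 remains modestly apart from the simple butyl amine, a 2.6-fold higher number from compound 1 to compound 4 (0.42 log units; beyond the scatter). The step out of compound 2 can be read only as a lower bound, because compound 2 is held at a limit of the assay and not at a number: the limit of > 10000 nM in this assay, at which 1 of the 4 values shown sits.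

Still open, as far as these compounds go, is whether a ring on the carbonyl carbon is needed at all or whether bulk alone suffices, a question that a longer open chain such as pentyl, or a small ring such as cyclopropyl, in the same place would address. Also open, from the compounds shown here alone, is how far the ring itself can be varied, for instance whether piperidin-4-yl, with a ring amine where oxan-4-yl has its oxygen, would stay level with compound 4.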